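This account rests on a few compounds, and the source may have more. Where it says the series, first, only, none or still open, it means among the compounds named here.

Measured set in an assay on cells (Oocyte) for negative allosteric modulation of glutamate receptor ionotropic, NMDA 2D (Rattus norvegicus), read by two-electrode voltage clamp; a lower number here means a stronger inhibitor, a higher number a weaker inhibitor:
Compound 1 `Cc1ccc(-c2c(C3=NN(C(=O)CCC(=O)O)C(c4ccc(Cl)cc4)C3)c(=O)[nH]c3ccccc23)cc1` gives 1400 nM.
Compound 2 `Cc1cccc(-c2c(C3=NN(C(=O)CCC(=O)O)C(c4ccc(Cl)cc4)C3)c(=O)[nH]c3ccccc23)c1` gives 1900 nM.
Compound 3 `O=C(O)CCC(=O)N1N=C(c2c(-c3ccc(F)c(Cl)c3)c3ccccc3[nH]c2=O)CC1c1ccc(Cl)cc1` gives 1000 nM.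

Compound 3 stands at the low end of a narrow spread, but the steps reaching it, a 1.4-fold lower number from compound 1 to compound 3 (0.15 log units; within the scatter) and a 1.9-fold lower number from compound 2 to compound 3 (0.28 log units; within the scatter), are both within the scatter, so the three numbers do not separate.

Compound 4 `O=C(O)CCC(=O)N1N=C(c2c(-c3cc(Cl)cc(Cl)c3)c3ccccc3[nH]c2=O)CC1c1ccc(Cl)cc1` is not yet measured. It differs from compound 3 by 3,5-dichlorophenyl in place of 3-chloro-4-fluorophenyl on an aromatic carbon. Every measured step in this set swaps the aryl group on that same aromatic carbon: a 1.4-fold higher number from compound 1 to compound 2 (0.13 log units; within the scatter), a 1.4-fold lower number from compound 1 to compound 3 (0.15 log units; within the scatter) and a 1.9-fold lower number from compound 2 to compound 3 (0.28 log units; within the scatter), all within the scatter. For the measured compounds named here, no measured pair trades one dichloro pattern for a chloro-fluoro pattern, so nothing points to a larger move. The step of a 1.1-fold higher number from compound 3 to compound 4 (0.04 log units; within the scatter) is therefore expected to stay within the scatter. Compound 4 is estimated at 1100 nM in this assay, range 500 nM to 2500 nM.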

Compound 4, half-maximal inhibitory concentration: 700 nM
Compound 4: middle estimate off by 1.6-fold (0.20 log units), on the high side; the range from low to high includes it.
By their numbers in this assay, from the lowest: compounds 4, 3, 1 and 2 (each within the scatter of the next, the first and the last beyond it).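

In this assay, the aryl position opposite the ring nitrogen gives its first step beyond the scatter (a 2.7-fold lower number from compound 2 to compound 4 (0.43 log units; beyond the scatter)), with 3,5-dichlorophenyl in place of 3-methylphenyl. The other two steps (a 1.4-fold lower number from compound 3 to compound 4 (0.15 log units; within the scatter)) and (a 2.0-fold lower number from compound 1 to compound 4 (0.30 log units; within the scatter)) stay within the scatter, so 3,5-dichlorophenyl separates from 3-methylphenyl only, and the effect remains modest. No outside evidence bears on this step. Still open, from the compounds shown here alone, is whether an amine or a carboxylic acid on this aryl ring would move the number beyond the scatter from compound 4. A single-chlorine 3-chlorophenyl group would show whether both chlorines are needed.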